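The source may hold more compounds than are shown below. What is called first, only, known or untested is meant among the compounds shown, and "the series" means these compounds.

Two compounds sharing one core have so far been examined in a functional assay on HO8910 cells (Homo sapiens) for inhibition, read by MTT assay, with a stated time of 24 h, tested at 10 ug/mL (a higher number here means more inhibition of growth at the concentration tested, a lower number less inhibition of growth), and only one of them has yielded a number. Compound 1 (`O=C(CCCCC(S)CCS)Nc1ccccn1`) is reported as "not active" (no number reported) with no figure attached. Compound 2 (`O=C(CCCCC(S)CCS)Nc1ccc(Cl)cn1`) gives 21.9% and thus holds the only figure available, with no other number to be ranked against. Compound 3 (`O=C(CCCCC(S)CCS)Nc1ccc(Br)cn1`) has not yet been measured. Its structure departs from that of compound 2 in a single place (bromo in place of chloro on an aromatic carbon): bromo in place of chloro on an aromatic carbon, two atoms from the ring nitrogen and para to a large group. Within the data shown here, no measured pair differing in one place exists, so the data give no direct size for such an exchange. In this assay no step beyond the usual scatter is expected, and neither direction is favoured. This expectation rests on compound 2 at 21.9% as the closest reading. The estimated step (a number 1.1 percentage points higher from compound 2 to compound 3 (within the scatter)) is accordingly small. For compound 3 the expected inhibition is 23% (estimated range 8% to 40%) when it is measured.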

Compound 3, percent growth inhibition at one concentration: 29.4%
The estimate for compound 3 lay 6.4 percentage points below the measured number, and the stated range covers the measured number.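

In this assay this position now has its first measured step, and the exchange of chloro for bromo, on an aromatic carbon two atoms from the ring nitrogen and para to a large group, gives a number 7.5 percentage points higher from compound 2 to compound 3 (within the scatter). Among these compounds, the readings therefore do not separate the two groups, which the single number available earlier could not show. Among the three compounds, both with a halogen at this place carry a number, whereas compound 1, which has no halogen there, is reported as "not active" (no number reported); nothing available bears on what lies behind these readings.

Going by these compounds, it remains open whether other groups at this place, such as fluoro, methyl, an amine or a carboxylic acid, would give readings like those of compound 2 and compound 3, and whether iodo would continue the series. Also open are how a longer chain in place of the one in the shared core would read and how any of these compounds would behave at concentrations other than the single one tested.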